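Furan in place of pyridine on the shared core

The compounds below may be only part of what the source reports. "The series", "measured", "known", "first", "only" and "open" are said of these compounds alone.

Compound 2 `c1ccc(-c2ccncc2)c(OCC2=NCCN2)c1` was tested in a functional assay for activation of Alpha-1D adrenergic receptor (Homo sapiens), read by calcium flux; a lower number here means that less compound is needed, a higher number that more compound is needed for the effect. In this assay compound 2 gives only a limit, < 100000 nM, not a number. Compound 1 `c1cncc(-c2ccccc2OCC2=NCCN2)c1` gives 158 nM in this assay. Compound 3 `Cc1ccnc(-c2ccccc2OCC2=NCCN2)c1` also returns only a limit in this assay, < 100000 nM. Going by the values given here, the one measured step that touches compound 2, a step that the limit leaves unreadable from compound 1 to compound 2, cannot be sized; the limit of < 100000 nM in this assay, at which 2 of the 3 values shown sit, marks where two of the three values sit. Compound 4 `c1ccc(-c2ccoc2)c(OCC2=NCCN2)c1` carries furan-3-yl in place of pyridin-4-yl on an aromatic carbon. Among the compounds with values here, no measured step covers this exchange, so only the values of compound 1 and compound 2 guide the expectation, and compound 2 offers just a limit. Compound 4 is therefore expected at 3000 nM, within 150 nM to 100000 nM, which would mean an estimated step that the limit leaves unreadable from compound 2 to compound 4.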

Compound 4, half-maximal effective concentration: 5.01 nM
Compound 4: the middle estimate sits 600-fold (2.78 log units) above what was measured; measured number below the stated range.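

In this assay, furan-3-yl in place of pyridin-3-yl gives a 32-fold lower number from compound 1 to compound 4 (1.50 log units; beyond the scatter), so a low number at this position does not depend on a pyridine ring. A five-membered aromatic ring is accepted here as well as a six-membered one. Compound 2 gives only a limit, so the steps that touch it cannot be read: the limit of < 100000 nM in this assay, at which 2 of the 4 values shown sit.

The compounds shown leave open whether the ring's oxygen matters, which a thiophen-3-yl or a plain phenyl group on the same carbon could test. They also leave open how furan-2-yl would compare.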